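Chloro to trifluoromethyl in the acid series

A few compounds are considered here, and "the series" means these few. Any claim that something is new, unique, unknown or untested is made for them only; others in the source may bear on it.

In a physicochemical assay for lipophilicity, at pH 7.4 (on this read-out lower numbers stand for lower lipophilicity and higher numbers for higher lipophilicity), compound 1 `CC(C(=O)O)c1nn(Cc2cn3cc(OCC4CC4)c(Cl)cc3n2)c2ccccc2c1=O` gives 2.44, compound 2 `C[C@@H](C(=O)O)c1nn(Cc2cn3cc(OCC4CC4)c(Cl)cc3n2)c2ccccc2c1=O` gives 2.41 and compound 3 `O=C(O)C1(c2nn(Cc3cn4cc(OCC5CC5)c(Cl)cc4n3)c3ccccc3c2=O)CC1` gives 2.46 on the same scale. These three values lie within the scatter of one another, so compound 1 holds no distinct place among them.

The stereo difference gives a number 0.03 log units lower from compound 1 to compound 2 (within the scatter). Placing 1-carboxycyclopropyl in place of 1-carboxyethyl gives a number 0.02 log units higher from compound 1 to compound 3 (within the scatter) and also a number 0.05 log units higher from compound 2 to compound 3 (within the scatter).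

Compound 4 `CC(C(=O)O)c1nn(Cc2cn3cc(OCC4CC4)c(C(F)(F)F)cc3n2)c2ccccc2c1=O` remains unmeasured. Its difference from compound 1 is trifluoromethyl in place of chloro on an aromatic carbon, with trifluoromethyl in place of chloro on an aromatic carbon, ortho to a cyclopropylmethoxy group. Among the compounds with values here, none of the measured steps touches the chloro group, so none gives a direct measure of this change. Within the data shown here, they show only that these three compounds stay within the scatter when the other parts vary.

The expectation therefore rests on the structural change alone, starting from compound 1 at 2.44 in this assay. A small upward step is expected, and it may not clear the scatter. The expected step is a number 0.20 log units higher from compound 1 to compound 4 (within the scatter) in this estimate. For compound 4 the estimated value is 2.64, with an expected range from 2.35 to 2.95.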

Compound 4, distribution coefficient: 2.99
Estimate against measurement, compound 4: 0.35 log units below; the whole stated range lies below it.
By their numbers in this assay, from the lowest: compounds 2, 1 and 3 (each within the scatter of the next); then compound 4.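

In this assay, within the data shown here, the place ortho to a cyclopropylmethoxy group gives the first step in this acid series that clears the scatter: trifluoromethyl in place of chloro gives a number 0.55 log units higher from compound 1 to compound 4 (beyond the scatter) on the shared core. The earlier steps shown here all changed the acid side chain or how its stereocentre is drawn and all stayed within the scatter, so the read-out responds at this place in a way those compounds could not show. The pair shows only the size and direction of the step, and nothing measured here explains why it has this size.

Among these compounds, it remains open whether a step of similar size appears when trifluoromethyl is combined with the 1-carboxycyclopropyl group of compound 3 or the defined configuration of compound 2, since the single pair here carries 1-carboxyethyl drawn without a configuration. Also open, going by these compounds, is where other groups at this same place, such as a methyl group, a nitrile or a bromine atom, would fall relative to chloro and trifluoromethyl, and so whether this single exchange reflects a broader trend at the position.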